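Adding dimethylamino to the weakest compound of the series

This account rests on a few compounds, and the source may have more. Where it says the series, first, only, none or still open, it means among the compounds named here.

Three hydroxamic acids have been measured in a functional assay on A2780cisR cells (Homo sapiens) for cytotoxicity, read by MTT assay, with a stated time of 72 h; on this read-out lower numbers stand for stronger inhibition and higher numbers for weaker inhibition. Compound 1 `O=C(CCCCCN(CC(=O)NC1CCCCC1)C(=O)c1ccccc1)NO` gives 8210 nM, compound 2 `CCCCNC(=O)CN(CCCCCC(=O)NO)C(=O)c1ccc(N(C)C)cc1` gives 3190 nM, and compound 3 `CC(C)(C(=O)NC1CCCCC1)N(CCCCCC(=O)NO)C(=O)c1ccccc1` gives 281000 nM. Compound 3 therefore has the highest number of the three, and its distance from each of the others lies beyond the scatter.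

The next structure is compound 4 `CN(C)c1ccc(C(=O)N(CCCCCC(=O)NO)C(C)(C)C(=O)NC2CCCCC2)cc1`, which is compound 3 with dimethylamino in place of hydrogen on an aromatic carbon, para to a large group: dimethylamino in place of hydrogen on an aromatic carbon. Among the measured compounds shown here, no measured pair isolates this change. Compound 2 already carries the 4-(dimethylamino)phenyl group and gives 3190 nM, but it differs from the other two compounds in more than one place, so its value cannot be credited to that group alone. A move toward a lower number is expected on this weak evidence, while most of the distance back to the other two compounds is expected to remain. The estimated step of a 5.6-fold lower number from compound 3 to compound 4 (0.75 log units; beyond the scatter) is expected to be moderate and beyond the scatter, though with wide uncertainty. For compound 4 the expected value is 50000 nM, with an estimated range from 8000 nM to 280000 nM.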

Compound 4, half-maximal inhibitory concentration: 107000 nM
Beside the measured number, compound 4's estimate is 2.1-fold (0.33 log units) below it; low and high end bracket the measured number.
By their numbers in this assay, from the lowest: compound 2; then compound 1; then compound 4; then compound 3.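

The pair gives the series its first single-place reading in this assay: dimethylamino in place of hydrogen on an aromatic carbon, para to a large group, brings a 2.6-fold lower number from compound 3 to compound 4 (0.42 log units; beyond the scatter) as a modest change. This position therefore accepts a group of three heavy atoms, with no ring and no net charge, and the number moves toward stronger inhibition rather than weaker. The reading rests on this one pair and on the background of compound 3, and no accompanying measurement bears on why the number moves.

Whether the same replacement gives a step of similar size on the background of compound 1 or on any other part of the series remains open, as the compounds shown offer only this one pair. Also open, going by these compounds, is how other groups at the same ring position would compare with dimethylamino, for example a primary amine, a methoxy group or a carboxylic acid, which would show whether this step is specific to dimethylamino or is shared by other replacements of that hydrogen.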